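Replacing the Methoxyphenyl Arm: What Compound 4 May Give

The compounds below may be only part of what the source reports. "The series", "measured", "known", "first", "only" and "open" are said of these compounds alone.

Compound 1 `O=C(/C(=C\c1ccc(Cl)cc1Cl)S(=O)(=O)c1ccc(Br)cc1)c1ccc(Br)cc1`: 10000 nM
Compound 2 `O=C(/C(=C\c1ccc(F)cc1)S(=O)(=O)c1ccc(Br)cc1)c1ccc(Br)cc1`: 4000 nM
Compound 3 `COc1ccc(/C=C(\C(=O)c2ccc(Br)cc2)S(=O)(=O)c2ccc(Br)cc2)cc1`: 25000 nM

In a functional assay on DU-145 cells (Homo sapiens) for inhibition, read by trypan blue exclusion, with a stated time of 96 h (a lower number here means a stronger inhibitor of growth, a higher number a weaker inhibitor of growth), compound 3 gives the highest number of the three; compound 1 is its nearest neighbour, as a 2.5-fold higher number from compound 1 to compound 3 (0.40 log units; beyond the scatter) shows, and compound 2 the furthest, as a 6.3-fold higher number from compound 2 to compound 3 (0.80 log units; beyond the scatter) shows. Compound 4 `O=C(/C(=C\c1ccc(F)c([N+](=O)[O-])c1)S(=O)(=O)c1ccc(Br)cc1)c1ccc(Br)cc1` differs from compound 3 by 4-fluoro-3-nitrophenyl in place of 4-methoxyphenyl on a double-bonded chain carbon bound to a double-bonded chain carbon. The step that bears most on this is a 6.3-fold higher number from compound 2 to compound 3 (0.80 log units; beyond the scatter), since compound 4 carries a fluoro on that ring as compound 2 does; read backwards it points to a lower number. The nitro group has no precedent among these three compounds, so it widens the uncertainty. Compound 4 is therefore expected to give 5000 nM in this assay, within 1500 nM to 20000 nM, which means an expected step of a 5.0-fold lower number from compound 3 to compound 4 (0.70 log units; beyond the scatter).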

Compound 4, concentration for 50% growth inhibition: 25000 nM
Beside the measured number, compound 4's estimate is 5.0-fold (0.70 log units) below it; the whole stated range lies below it.
By their numbers in this assay, from the lowest: compound 2; then compound 1; then compounds 3 and 4 (each within the scatter of the next).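

In this assay, nitro in place of hydrogen on an aromatic carbon gives a 6.3-fold higher number from compound 2 to compound 4 (0.80 log units; beyond the scatter) and so shows that a fluoro on this ring does not by itself bring the lower number. The 4-fluoro-3-nitrophenyl arm stands level with the 4-methoxyphenyl arm, with no change at the digits printed from compound 3 to compound 4 (within the scatter) for that change, while a 2.5-fold higher number from compound 1 to compound 4 (0.40 log units; beyond the scatter) marks its change from the 2,4-dichlorophenyl arm at this position. Nothing measured here accounts for these steps.

The compounds shown leave open whether an amine in place of the nitro on this ring would return the lower number.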